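Heteroaryl exchange on a nitrophenylsulfonamide and expected cytotoxicity

This account rests on a few compounds, and the source may have more. Where it says the series, first, only, none or still open, it means among the compounds named here.

compound 1 `O=[N+]([O-])c1ccc(S(=O)(=O)Nc2cnccn2)cc1` — > 256000 nM
compound 2 `O=[N+]([O-])c1ccc(S(=O)(=O)Nc2cccnc2)cc1` — "not determined" (no result reported)
compound 3 `O=[N+]([O-])c1ccc(S(=O)(=O)Nc2nccs2)cc1` — "not determined" (no result reported)

In an ADME assay on J774 cells (Mus musculus) for cytotoxicity, read by resazurin assay, with a stated time of 24 h (a higher number here means a weaker inhibitor, a lower number a stronger inhibitor), compound 1 gives > 256000 nM, which is a limit of the assay and not a number. Compound 2 has no result in this assay, recorded as "not determined" (no result reported). Compound 3 likewise has no result in this assay, recorded as "not determined" (no result reported). Compound 3 therefore stands without a number of its own; of the two other entries in this assay, one is a limit and one is empty, so the only point of reference for the series is the limit of > 256000 nM in this assay, at which 1 of the 3 values shown sits. Going by the values given here, no step between measured compounds can be drawn from these three entries.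

Compound 4 `Cc1cc(NS(=O)(=O)c2ccc([N+](=O)[O-])cc2)no1` differs from compound 3 by 5-methyl-1,2-oxazol-3-yl in place of 1,3-thiazol-2-yl on a sulfonamide nitrogen. Among the compounds with values here, with no measured step in this assay, the size of the step from compound 3 to compound 4 cannot be anchored, and the expectation is for no movement beyond the scatter, in neither direction, with the result most likely again reported as a limit. Compound 4 is accordingly estimated to give about 256000 nM in this assay, with a range from 100000 nM to 300000 nM.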

Compound 4, half-maximal inhibitory concentration: > 256000 nM
Compound 4: only a limit was reported; the forecaster's own chance of this, stated with the estimate: 85%; the middle value sits exactly at the limit.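

In this assay, no step can be read from compound 1 to compound 4, since both entries are limits of the assay and not numbers: the limit of > 256000 nM in this assay, at which 2 of the 4 values shown sit.

The compounds shown leave open whether exchanging the group on the sulfonamide nitrogen changes the result in this assay at all, as none of the four has a single number.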